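The source may hold more compounds than are shown below. What is called first, only, known or untested is meant among the compounds shown, and "the series" means these compounds.

Measured in a functional assay on MDA-MB-231 cells (Homo sapiens) for antiproliferative activity, with a stated time of 4 days; a lower number here means a stronger inhibitor, a higher number a weaker inhibitor:
compound 1 `CCCCc1ccc2[nH]c(-c3ccc(OC)cc3)c(/C=N/NC(=O)c3ccccc3)c2c1` gives 32 nM
compound 2 `CCCCc1ccc2[nH]c(-c3ccc(OC)cc3)c(/C=N/NC(=O)c3ccc(Cl)cc3)c2c1` gives 90 nM
compound 3 `CCCCc1ccc2[nH]c(-c3ccc(C(F)(F)F)cc3)c(/C=N/NC(=O)c3ccc(Cl)cc3)c2c1` gives 329 nM

Compound 2 (90 nM) stands in the middle of these three numbers, with compound 1 (32 nM) lower and compound 3 (329 nM) higher. Compound 4 `CCCCc1ccc2[nH]c(-c3ccc(OC)cc3)c(/C=N/NC(=O)c3ccccc3OC)c2c1` has not yet been measured. It differs from compound 2 in one place: 2-methoxyphenyl in place of 4-chlorophenyl on a carbonyl carbon and the rest of the structure is shared.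

The closest guide is a 2.8-fold higher number from compound 1 to compound 2 (0.45 log units; beyond the scatter) (modest), where chloro replaces hydrogen on an aromatic carbon. Compound 4 also lacks that chloro, which points toward the lower number of compound 1. The other measured step, a 3.7-fold higher number from compound 2 to compound 3 (0.56 log units; beyond the scatter) (also modest), swaps methoxy for trifluoromethyl, a change compound 4 does not carry, so it bears on this comparison only as a measure of typical step size. Going by the values given here, no measured compound has a 2-methoxyphenyl, so the contribution of that group remains open.

In this assay a small move toward a lower number is therefore expected, smaller than the step that came with chloro. The estimated step is a 1.5-fold lower number from compound 2 to compound 4 (0.18 log units; within the scatter) and it may stay within the scatter. Compound 4 is estimated at 60 nM (expected range 20 nM to 180 nM).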

Compound 4, half-maximal inhibitory concentration: 21 nM
Compound 4: middle estimate off by 2.9-fold (0.46 log units), on the high side, and the stated range covers the measured number.
By their numbers in this assay, from the lowest: compounds 4 and 1 (each within the scatter of the next); then compound 2; then compound 3.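

In this assay, 2-methoxyphenyl in place of 4-chlorophenyl on a carbonyl carbon gives a 4.3-fold lower number from compound 2 to compound 4 (0.63 log units; beyond the scatter), a step beyond the scatter, so the position tolerates a group other than hydrogen without the higher number that came with chloro in a 2.8-fold higher number from compound 1 to compound 2 (0.45 log units; beyond the scatter). The comparison with the compound lacking any group on that ring gives a 1.5-fold lower number from compound 1 to compound 4 (0.18 log units; within the scatter), which lies within the scatter: compound 1 at 32 nM and compound 4 at 21 nM cannot be told apart here, so the earlier link between a group on this ring and a higher number holds for chloro but not for methoxy. Nothing available explains why chloro and methoxy part ways at this position.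

On these data alone, whether a hydroxyl or an amine in place of the methoxy of 2-methoxyphenyl would stay in the range of compound 1 and compound 4 remains open. Also open, as far as these compounds go, is whether the step seen on going from methoxy to trifluoromethyl with 4-chlorophenyl on the carbonyl carbon would hold with 2-methoxyphenyl there.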